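The compounds below may be only part of what the source reports. "The series", "measured", "known", "first", "only" and "open" are said of these compounds alone.

Two compounds of the series share one core and differ only in the aryl group on the sulfonyl sulfur. Compound 1 `COc1ccc2ncc(S(=O)(=O)c3cccc(C#N)c3)c(N3CCC(C)CC3)c2c1` carries a 3-cyanophenyl there; in an assay on isolated protein for displacement of a labelled ligand from metabotropic glutamate receptor 5 (Homo sapiens), with a stated time of 60 min, tested at 1 uM (a higher number here means more inhibition at the concentration tested (going by the name of the read-out), a lower number less inhibition), compound 1 gives 90%. Compound 2 `COc1ccc2ncc(S(=O)(=O)c3cc(F)cc(F)c3)c(N3CCC(C)CC3)c2c1` carries a 3,5-difluorophenyl instead, and in this assay compound 2 gives 30%. Going by the values given here, the step of a number 60 percentage points lower from compound 1 to compound 2 (beyond the scatter) is the only measured step so far. On the numbers seen, compound 2 stands lowest of the two, with compound 1 the nearest comparison and beyond the scatter above it.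

Compound 3 `COc1ccc2ncc(S(=O)(=O)c3ccc(F)cc3)c(N3CCC(C)CC3)c2c1` has not yet been measured. It differs from compound 2 as follows: 4-fluorophenyl in place of 3,5-difluorophenyl on a sulfonyl sulfur. Among the compounds with values here, no measured step covers a 4-fluorophenyl on the sulfonyl sulfur. Within the data shown here, the one step that bears on the change, a number 60 percentage points lower from compound 1 to compound 2 (beyond the scatter), shows that exchanging the aryl group at this position can move this assay by a large amount, and in that case the 3,5-difluorophenyl gave the weaker result. As far as these compounds go, whether the 4-fluorophenyl recovers inhibition is unknown, so the expectation is wide. The expected step is a number 20 percentage points higher from compound 2 to compound 3 (beyond the scatter), upward, with low confidence. Compound 3 is estimated at 50% in this assay, within a range from 15% to 85%.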

Compound 3, a percentage reported as inhibition, at one concentration (the size of the read-out at that concentration, not a potency): 27%
Beside the measured number, compound 3's estimate is 23 percentage points above it; the range from low to high includes it.
By their numbers in this assay, from the lowest: compounds 3 and 2 (each within the scatter of the next); then compound 1.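

In this assay the new result gives a number 3 percentage points lower from compound 2 to compound 3 (within the scatter) for this change on the sulfonyl sulfur, so the 4-fluorophenyl and the 3,5-difluorophenyl cannot be told apart here, and the difference between one fluorine and two on the aryl ring leaves no readable mark on this series. Measured against the 3-cyanophenyl, the same group gives a number 63 percentage points lower from compound 1 to compound 3 (beyond the scatter) and thereby shows that the large gap seen earlier was not particular to the 3,5-difluorophenyl; among the three compounds the high reading occurs only with the 3-cyanophenyl, and none of them goes against this. Nothing available explains why the 3-cyanophenyl stands apart from the two fluorophenyl groups.

As far as these compounds go, it remains open whether the high reading depends on the nitrile itself or would also appear with another group on the aryl ring, such as an amide or a carboxylic acid in its place. A plain phenyl on the sulfonyl sulfur would show whether the fluorine-bearing rings sit close to the baseline of the series or whether the fluorines themselves bear on the reading.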